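The compounds below may be only part of what the source reports. "The series", "measured", "known", "first", "only" and "open" are said of these compounds alone.

Of the compounds shown here, three built on one shared core have so far been tested in an ADME assay on microsomes from liver (Rattus norvegicus) for metabolic stability; a higher number here means that the compound lasts longer, a lower number that the compound disappears faster. Compound 1 `CC(C)C(c1ccc(-c2ccc3cccc(F)c3c2)[nH]c1=O)N1CCCCS1(=O)=O` gives 0.07 h in this assay. Compound 2 `CC(C)C(Nc1nnc[nH]1)c1ccc(-c2ccc3cccc(F)c3c2)[nH]c1=O` gives 1.29 h, and the step of an 18-fold higher number from compound 1 to compound 2 (1.27 log units; beyond the scatter). Compound 3 `Cc1c[nH]c(C(c2ccc(-c3ccc4cccc(F)c4c3)[nH]c2=O)C(C)C)n1` returns only a limit of the assay, < 0.0667 h. Compound 3 thus stands at the limit of < 0.0667 h in this assay, at which 1 of the 3 values shown sits. Going on from compound 2, the step of an at least 19-fold lower number from compound 2 to compound 3 (1.28 log units; beyond the scatter), whereas an at least 1.0-fold lower number from compound 1 to compound 3 (0.02 log units; that floor lies within the scatter).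

Compound 4 `CC(C)C(Cc1noc(=O)[nH]1)c1ccc(-c2ccc3cccc(F)c3c2)[nH]c1=O` has not yet been measured in this assay. It differs from compound 3 by a group of 7 heavy atoms (3 carbon, 2 nitrogen, 2 oxygen; one five-membered aromatic ring with 3 hetero atoms) in place of a group of 6 heavy atoms (4 carbon, 2 nitrogen; one five-membered aromatic ring with 2 hetero atoms), on a saturated chain carbon bound to an aromatic carbon and a saturated chain carbon. Within the data shown here, two measured steps bear on this change, both large and both made on the same saturated chain carbon: the step from compound 1 to compound 2 and the step from compound 2 to compound 3. The group that enters compound 4 shares with compound 2 a five-membered aromatic ring with 3 hetero atoms, but its direction in this assay cannot be read from the three values. Compound 4 is therefore expected to give about 0.2 h in this assay, within a range from 0.05 h to 0.8 h. That estimate means an expected step of an at least 2.9-fold higher number from compound 3 to compound 4 (0.47 log units; beyond the scatter), and a reading at the limit remains possible.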

Compound 4, half-life: > 3 h
Compound 4: no number, only a limit; the forecaster's own chance of this, stated with the estimate: 30%; at least 15-fold (1.17 log units) between middle value and limit.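

In this assay compound 4 gives a limit of the assay rather than a number, so its reading marks the top of the range shown: the limit of > 3 h in this assay, at which 1 of the 4 values shown sits. On the same saturated chain carbon, the group entering compound 4 brings clear gains over all three earlier groups: an at least 44-fold higher number from compound 3 to compound 4 (1.65 log units; beyond the scatter), an at least 42-fold higher number from compound 1 to compound 4 (1.63 log units; beyond the scatter) and an at least 2.3-fold higher number from compound 2 to compound 4 (0.36 log units; beyond the scatter). A second group with a five-membered aromatic ring with 3 hetero atoms now gives a high reading, so compound 2 is no longer alone among the four compounds, yet the two still part beyond the scatter, which shows that having such a ring does not fix the reading.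

Going by these compounds, how far compound 4 lies past its limit stays open. So does whether a carboxylic acid on this saturated chain carbon would last as long as the ring of compound 4.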